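2-methoxyphenyl in place of 4-bromophenyl: working notes

The compounds below may be only part of what the source reports. "The series", "measured", "known", "first", "only" and "open" are said of these compounds alone.

- Compound 1 (`COc1ccc(/C=C2\CCC/C(=C\c3cccc(Br)c3)C2=O)cc1OC`): 12800 nM
- Compound 2 (`COc1ccc(/C=C2\CCC/C(=C\c3ccc(Br)cc3)C2=O)cc1OC`): 16000 nM

Among the measured compounds shown here, in a functional assay on A549 cells (Homo sapiens) for cytotoxicity, read by MTT assay, with a stated time of 72 h (a higher number here means a weaker inhibitor, a lower number a stronger inhibitor), compound 2 gives 16000 nM and stands within the scatter of compound 1, the only other measured compound. Compound 3 (`COc1ccccc1/C=C1\CCC/C(=C\c2ccc(OC)c(OC)c2)C1=O`) has not yet been measured. Its difference from compound 2 is 2-methoxyphenyl in place of 4-bromophenyl on a double-bonded chain carbon bound to a double-bonded ring carbon and it amounts to 2-methoxyphenyl in place of 4-bromophenyl on a double-bonded chain carbon bound to a double-bonded ring carbon.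

For the measured compounds named here, the one measured step at this place is a 1.3-fold higher number from compound 1 to compound 2 (0.10 log units; within the scatter) and it stays within the scatter. On that basis no step beyond the scatter is expected in this assay and neither direction is favoured. Going by the values given here, the support is thin: that step only exchanges one bromophenyl for another, and no measured compound carries 2-methoxyphenyl here, so the range is kept wide.

The estimated value for compound 3 is 14000 nM with an expected range from 6000 nM to 32000 nM for repeat measurements. This estimate means an expected 1.1-fold lower number from compound 2 to compound 3 (0.06 log units; within the scatter) and so no change beyond the scatter.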

Compound 3, half-maximal inhibitory concentration: > 20000 nM
Compound 3 ended at the assay's limit (the forecaster's own chance of this, stated with the estimate: 10%); at least 1.4-fold (0.15 log units) between middle value and limit.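

In this assay, compound 3 ends at a limit of the assay and not at a number: the limit of > 20000 nM in this assay, at which 1 of the 3 values shown sits. The steps to it are therefore floors only, with 2-methoxyphenyl in place of 4-bromophenyl giving an at least 1.2-fold higher number from compound 2 to compound 3 (0.09 log units; that floor lies within the scatter) and 2-methoxyphenyl in place of 3-bromophenyl giving an at least 1.5-fold higher number from compound 1 to compound 3 (0.19 log units; that floor lies within the scatter). The earlier exchange of one bromophenyl for another covered only bromophenyl groups at this place on a double-bonded chain carbon bound to a double-bonded ring carbon, whereas compound 3 adds a group without bromine, and it brings no lower number than either bromophenyl compound, though both floors lie within the scatter.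

Going by these compounds, whether the true step to compound 3 goes beyond the scatter stays open, since a limit gives it no upper end. Also open, on these data alone, is how this place responds to other groups: 4-methoxyphenyl would show whether compound 3's result holds when the methoxy group sits as the bromine does in compound 2, and a phenyl ring bearing an amine or a carboxylic acid would test a different kind of substituent on the shared core.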